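Benzyl ring hydroxylation in a nucleoside series

The source may report more compounds than this note shows. Statements on the series, on what has been measured and on what is new or still open speak of the compounds shown alone.

Compound 2 `Cc1cccc(CNc2ncnc3c2ncn3[C@@H]2O[C@H](CO)[C@@H](O)[C@H]2O)c1` is one of three measured members of the series. In a functional assay on B16 cells (Mus musculus) for antiproliferative activity, with a stated time of 72 h (on this read-out lower numbers stand for stronger inhibition and higher numbers for weaker inhibition), compound 2 reaches only the assay limit of > 166000 nM. Compound 1 `OC[C@H]1O[C@@H](n2cnc3c(NCc4ccccc4Br)ncnc32)[C@H](O)[C@@H]1O` likewise reaches only a limit, > 166000 nM in this assay. Compound 3 `OC[C@H]1O[C@@H](n2cnc3c(NCc4ccc(F)c(Cl)c4)ncnc32)[C@H](O)[C@@H]1O` gives 167000 nM in this assay, a number at the top of the tested range. The steps a step that the two limits leave unreadable from compound 1 to compound 2, a step that the limit leaves unreadable from compound 1 to compound 3 and a step that the limit leaves unreadable from compound 2 to compound 3 are therefore unreadable; all that is seen is the limit of > 166000 nM in this assay, at which 2 of the 3 values shown sit. Compound 4 `Cc1ccc(O)c(CNc2ncnc3c2ncn3[C@@H]2O[C@H](CO)[C@@H](O)[C@H]2O)c1` differs from compound 2 by hydroxy in place of hydrogen on an aromatic carbon. For the measured compounds named here, no measured step bears on a hydroxy group, and no aryl change has moved the read-out off its ceiling, so no step beyond the scatter is expected for a step that the limit leaves unreadable from compound 2 to compound 4. Compound 4 is expected at 170000 nM, range 120000 nM to 250000 nM, most likely again reported as a limit.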

Compound 4, half-maximal inhibitory concentration: > 166000 nM
Compound 4: a limit, no number (the forecaster's own chance of this, stated with the estimate: 80%); the middle value does not contradict the limit.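

Compound 4 gives > 166000 nM in this assay, a limit and not a number, so its steps from compound 1, compound 2 and compound 3 cannot be read: the limit of > 166000 nM in this assay, at which 3 of the 4 values shown sit.

The compounds shown leave open whether hydroxy in place of hydrogen on an aromatic carbon, or any of the aryl changes, affects this read-out at all.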